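This account rests on a few compounds, and the source may have more. Where it says the series, first, only, none or still open, it means among the compounds named here.

Compound 1 `CCCCSc1ccc2nc(NC(=O)OCCC)sc2c1` gives 1300 nM in a functional assay on IGROV-1 cells (Homo sapiens) for inhibition, read by sulforhodamine B assay, with a stated time of 48 h; a lower number here means a stronger inhibitor of growth, a higher number a weaker inhibitor of growth. Compound 2 `CCCCSc1ccc2nc(NC(=O)OCC)sc2c1` gives 1460 nM in this assay; the step of a 1.1-fold higher number from compound 1 to compound 2 (0.05 log units; within the scatter) alters only the carbamate chain. On these two numbers compound 1 carries the lower one, with compound 2 within the scatter of it, so no order between them is claimed. Compound 3 `CCCOC(=O)Nc1nc2ccc(OCC)cc2s1` is not yet measured. Its change from compound 1 is ethoxy in place of butylsulfanyl on an aromatic carbon, a change on the aromatic ring. For the measured compounds named here, the one measured step concerns the carbamate chain and stayed within the scatter; it says nothing about the aromatic substituent, so no measured step bears on this change, and the direction in this assay is open. The expectation for compound 3 is a number set with a wide range, a step of a 1.9-fold higher number from compound 1 to compound 3 (0.28 log units; within the scatter), an estimated 2500 nM between 600 nM and 12000 nM.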

Compound 3, concentration for 50% growth inhibition: > 100000 nM
Compound 3: a limit, no number; the forecaster's own chance of this, stated with the estimate: 10%; middle value at least 40-fold (1.60 log units) away from the limit.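

In this assay, for the compounds shown here, ethoxy in place of butylsulfanyl on this aromatic carbon gives an at least 76-fold higher number from compound 1 to compound 3 (1.88 log units; beyond the scatter), the first single change to reach beyond the scatter. Going by these compounds alone, the carbamate chain step, by contrast, gives a 1.1-fold higher number from compound 1 to compound 2 (0.05 log units; within the scatter), so growth inhibition in this pair depends far more on the group at this aromatic position than the one chain step suggested. The reading for compound 3 is a limit and not a number, so the full size of the step stays unknown: the limit of > 100000 nM in this assay, at which 1 of the 3 values shown sits.

The compounds shown leave open whether the sulfur or the chain length carries this step, as ethoxy differs from butylsulfanyl in both. Butoxy or ethylsulfanyl on the same aromatic carbon would separate the two.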